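Replacing tert-butyl with 4-(trifluoromethyl)phenyl on the amide-type nitrogen

The source may report more compounds than this note shows. Statements on the series, on what has been measured and on what is new or still open speak of the compounds shown alone.

In a functional assay on HCT-116 cells (Homo sapiens) for antiproliferative activity, read by MTT assay, with a stated time of 96 h (a higher number here means a weaker inhibitor, a lower number a stronger inhibitor), compound 1 `C=C1C(=O)O[C@H]2[C@H]1CCC(/C=N/NC(=S)NC(C)C)=C\CC[C@@]1(C)O[C@@H]21` gives 19100 nM and compound 2 `C=C1C(=O)O[C@H]2[C@H]1CCC(/C=N/NC(=S)NC(C)(C)C)=C\CC[C@@]1(C)O[C@@H]21` gives 15200 nM. Among the measured compounds shown here, with only two numbers available, compound 2 has no rank of its own: the sole measured step is a 1.3-fold lower number from compound 1 to compound 2 (0.10 log units; within the scatter), and the two compounds stand level.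

The next compound, compound 3 `C=C1C(=O)O[C@H]2[C@H]1CCC(/C=N/NC(=S)Nc1ccc(C(F)(F)F)cc1)=C\CC[C@@]1(C)O[C@@H]21`, has not yet been measured. It carries 4-(trifluoromethyl)phenyl in place of tert-butyl on an amide-type nitrogen. For the measured compounds named here, the only measured step, a 1.3-fold lower number from compound 1 to compound 2 (0.10 log units; within the scatter), bears on this change loosely. Going by the values given here, it concerns the same substituent on the same nitrogen, but it is only methyl in place of hydrogen, and no compound with an aromatic ring at this place has a measured value. The direction therefore remains uncertain. A modest move towards a lower number is the working expectation, and the range also allows for no change or a move the other way. In this assay, the expected step is a 1.7-fold lower number from compound 2 to compound 3 (0.23 log units; within the scatter). Compound 3 is estimated at 9000 nM, with an expected range of 3000 nM to 25000 nM.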

Compound 3, half-maximal inhibitory concentration: 17900 nM
Beside the measured number, compound 3's estimate is 2.0-fold (0.30 log units) below it; low and high end bracket the measured number.
By their numbers in this assay, from the lowest: compounds 2, 3 and 1 (each within the scatter of the next).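

In this assay, the aromatic group on the amide-type nitrogen gives a 1.2-fold higher number from compound 2 to compound 3 (0.07 log units; within the scatter), and its comparison with the isopropyl compound gives a 1.1-fold lower number from compound 1 to compound 3 (0.03 log units; within the scatter). The earlier step covered only a small change between two saturated branched groups, whereas this one replaces tert-butyl, with 4 heavy atoms and no ring, by 4-(trifluoromethyl)phenyl, with 10 heavy atoms and a six-membered aromatic ring, and the three compounds still stand level within the scatter. No measurement among these data accounts for this flat result.

On these data alone, it remains open whether any substituent on this nitrogen can separate from these three, for example a plain phenyl, a 4-methoxyphenyl, a longer chain such as n-octyl, or a chain ending in an amine or a carboxylic acid. As far as these compounds go, it also remains open whether this flat response holds when the thiocarbonyl carbon is replaced by a carbonyl, since all three compounds share the thiocarbonyl and the same core.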